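The source may report more compounds than this note shows. Statements on the series, on what has been measured and on what is new or still open speak of the compounds shown alone.

In a functional assay, read by Griess assay, with a stated time of 2.5 h (on this read-out lower numbers stand for stronger inhibition and higher numbers for weaker inhibition), compound 1 `COc1cc(OC)c(OC)cc1/C=C/C(=O)c1ccc(Cl)cc1` gives 2.01 ug/mL, compound 2 `COc1ccc(C(=O)/C=C/c2cc(OC)c(OC)cc2OC)cc1` gives 2.07 ug/mL and compound 3 `COc1cc(OC)c(OC)cc1/C=C/C(=O)c1ccc(O)cc1O` gives 2.76 ug/mL. Compound 3 therefore cannot be separated from the other two, as the data show a 1.3-fold higher number from compound 2 to compound 3 (0.12 log units; within the scatter) and a 1.4-fold higher number from compound 1 to compound 3 (0.14 log units; within the scatter). Compound 4 `COc1cc(OC)c(OC)cc1/C=C/C(=O)c1cc(Cl)ccc1O` keeps the shared core and differs from compound 3 at one place: 5-chloro-2-hydroxyphenyl in place of 2,4-dihydroxyphenyl on a carbonyl carbon, with 5-chloro-2-hydroxyphenyl in place of 2,4-dihydroxyphenyl on a carbonyl carbon. For the measured compounds named here, no measured step makes exactly this exchange. The closest evidence is the exchange of 4-chlorophenyl for 2,4-dihydroxyphenyl, a 1.4-fold higher number from compound 1 to compound 3 (0.14 log units; within the scatter), together with methoxy in place of chloro, a 1.0-fold higher number from compound 1 to compound 2 (0.01 log units; within the scatter). Neither step leaves the scatter, so no step beyond the scatter is expected in this assay, and the direction remains only a weak lean towards the chlorinated compound 1 at 2.01 ug/mL. The expected change is a 1.2-fold lower number from compound 3 to compound 4 (0.08 log units; within the scatter). The estimate for compound 4 is 2.3 ug/mL, with an expected range of 1.1 ug/mL to 4.8 ug/mL.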

Compound 4, half-maximal inhibitory concentration: 2.32 ug/mL
Beside the measured number, compound 4's estimate is 1.0-fold (0.00 log units) below it; measured number inside the range.
By their numbers in this assay, from the lowest: compounds 1, 2, 4 and 3 (each within the scatter of the next).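

In this assay, for the compounds shown here, 5-chloro-2-hydroxyphenyl on the carbonyl carbon gives no step that leaves the scatter, with a 1.2-fold lower number from compound 3 to compound 4 (0.08 log units; within the scatter), a 1.1-fold higher number from compound 2 to compound 4 (0.05 log units; within the scatter) and a 1.2-fold higher number from compound 1 to compound 4 (0.06 log units; within the scatter). Chlorine and hydroxy together on this ring therefore cannot be separated from 2,4-dihydroxyphenyl, 4-methoxyphenyl or 4-chlorophenyl, so all four groups shown at this position read alike in this assay. Nothing available here explains this lack of separation.

The compounds shown leave open whether an amine or a carboxylic acid on this ring, or a longer alkyl chain in place of the ring, would move the number beyond the scatter. They also leave open whether the same lack of separation would hold if the rest of the shared core were changed.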